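Benzoyl on the cytosine amine of compound 1

A few compounds are considered here, and "the series" means these few. Any claim that something is new, unique, unknown or untested is made for them only; others in the source may bear on it.

Measured so far:
compound 1 `Nc1ccn(C[C@H](O)[C@H]2OC(=O)C(OCc3ccccc3)=C2OCc2ccccc2)c(=O)n1` — 53900 nM
compound 2 `NC1(CCn2ccc(=O)[nH]c2=O)OC(=O)C(OCc2ccccc2)=C1OCc1ccccc1` — > 100000 nM

Among the measured compounds shown here, in an ADME assay on WI-38 cells (Homo sapiens) for inhibition, read by MTT assay, with a stated time of 72 h (a higher number here means a weaker inhibitor, a lower number a stronger inhibitor), compound 1 gives 53900 nM, the only numerical value so far. Compound 2 is recorded only as > 100000 nM, which is a limit of this assay and not a number. Compound 1 therefore stands as the sole fixed point; the other entry sits at the limit of > 100000 nM in this assay, at which 1 of the 2 values shown sits. For the measured compounds named here, no step between two measured compounds is available, so the size of a change from substitution on the shared core is unknown.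

Compound 3 `O=C1O[C@H]([C@@H](O)Cn2ccc(NC(=O)c3ccccc3)nc2=O)C(OCc2ccccc2)=C1OCc1ccccc1` differs from compound 1 by benzoyl in place of hydrogen on a nitrogen on an aromatic ring, amino to benzamido. Going by the values given here, with no measured step to rest on, the expectation is that compound 3 stays within the scatter of compound 1, with the step of a 1.3-fold lower number from compound 1 to compound 3 (0.13 log units; within the scatter) expected to be no larger than the usual spread. Compound 3 is estimated at 40000 nM, within 10000 nM to 150000 nM.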

Compound 3, half-maximal inhibitory concentration: 8820 nM
For compound 3 the middle estimate is 4.5-fold (0.66 log units) above the measured one, and the stated range ends above it.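

Among the compounds shown here, compound 1 and compound 3 give the first readable step: in this assay, benzoyl in place of hydrogen on a nitrogen on an aromatic ring gives a 6.1-fold lower number from compound 1 to compound 3 (0.79 log units; beyond the scatter). The free amino group is therefore not required for the inhibition seen here, and benzamido at this place gives the stronger inhibitor of the pair. For the compounds shown here, nothing measured so far gives a cause for this step.

From the compounds shown here alone, whether the step comes from the carbonyl or from the phenyl ring remains open, and an acetyl or a benzyl group on the same nitrogen would separate the two. Equally open, going by these compounds, is how a methoxy group or a chlorine on the benzoyl ring would move the number.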